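The compounds below may be only part of what the source reports. "The series", "measured", "known", "first", "only" and "open" are said of these compounds alone.

In an ADME assay on HepG2 cells (Homo sapiens) for cytotoxicity, read by CellTiter-Glo and resazurin assay, with a stated time of 72 h (on this read-out higher numbers stand for an effect only at larger amounts of compound and lower numbers for an effect already at smaller amounts), compound 3 `CCOC(=O)CCCCCOc1cccc(CN(C(=O)c2ccc(-c3cccc(C(C)=O)c3)cc2)C(C)C)c1` gives > 26000 nM, which is a limit of the assay and not a number. Compound 1 `CC(=O)c1cccc(-c2ccc(C(=O)N(Cc3cccc(OCCCCCC(=O)O)c3)C(C)C)cc2)c1` also sits at a limit: in this assay compound 1 gives > 26000 nM. Compound 2 `CC(C)N(Cc1cccc(OCCCCCC(=O)O)c1)C(=O)c1ccc(-c2cc3ccccc3n2S(=O)(=O)c2ccccc2)cc1` stands likewise at a limit, since in this assay compound 2 gives > 26000 nM. Within the data shown here, the single step measured between compounds that differ in one place, a step that the two limits leave unreadable from compound 1 to compound 3, cannot be read in size because of the limit of > 26000 nM in this assay, at which 3 of the 3 values shown sit. Compound 4 `CCOC(=O)CCCCCOc1cccc(CN(C(=O)c2ccc(-c3cccc(F)c3)cc2)C(C)C)c1` differs from compound 3 by fluoro in place of acetyl on an aromatic carbon. Among the measured compounds shown here, no measured step bears on this particular change, and every value that exists in this assay is a limit, so there is no measured size to carry over. The expectation is therefore that the step from compound 3 to compound 4 stays within the scatter, a step that the limit leaves unreadable from compound 3 to compound 4, with compound 4 most likely reported again as a limit. Compound 4 is estimated at 30000 nM, expected within the range from 15000 nM to 80000 nM.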

Compound 4, half-maximal effective concentration: > 26000 nM
Compound 4: no number, only a limit (the forecaster's own chance of this, stated with the estimate: 85%); the middle value lies beyond the limit too.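

The change from compound 3 to compound 4, fluoro in place of acetyl, yields no readable new step, because both compounds sit at the same kind of value: the limit of > 26000 nM in this assay, at which 4 of the 4 values shown sit.

The compounds shown leave open at what concentration any of them would produce a half-maximal effect in this assay, and whether this change alters it.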